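Replacing a Chloro with an Arylamino on the Shared Core

The compounds below may be only part of what the source reports. "The series", "measured", "known", "first", "only" and "open" are said of these compounds alone.

Compound 3 `N#Cc1c(Cl)nc(SCC(=O)Nn2c(COc3ccc(Cl)cc3Cl)nc3ccccc3c2=O)nc1-c1ccc(O)cc1` holds the top number of the three shown in a functional assay on the whole organism (strain albino) for inhibition, with Rattus norvegicus as the target, read by paw edema, with stated times of 1 h and 2 h, at a dose of 100 mg/kg by the oral route; a higher number here means more inhibition at the dose given (going by the name of the read-out), a lower number less inhibition: compound 3 gives 73.7%. The closest of the others is compound 2 `N#Cc1c(Cl)nc(SCC(=O)Nn2c(COc3ccc(Cl)cc3Cl)nc3ccccc3c2=O)nc1-c1ccc(Cl)cc1`, which gives 68.4%; the step of a number 5.3 percentage points higher from compound 2 to compound 3 (within the scatter) is within the scatter, so these two cannot be set in order. Compound 1 `O=C(CSc1nc(-c2ccc(O)cc2)c(C(=O)O)c(=O)[nH]1)Nn1c(COc2ccc(Cl)cc2Cl)nc2ccccc2c1=O` gives 38.6%, well below compound 3.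

Compound 4 `N#Cc1c(Nc2ccc(Cl)cc2)nc(SCC(=O)Nn2c(COc3ccc(Cl)cc3Cl)nc3ccccc3c2=O)nc1-c1ccc(O)cc1` differs from compound 3 in one place: (4-chlorophenyl)amino in place of chloro on an aromatic carbon. Only one measured step exists among these compounds, and it concerns a different change, a hydroxy in place of chloro on an aromatic carbon. Going by the values given here, no measured step bears on the present change, and nothing here shows what swapping a chloro for a (4-chlorophenyl)amino does. Among the compounds with values here, the data therefore give no direction for the step from compound 3 to compound 4, and a change no larger than the scatter is expected, a number 3.7 percentage points lower from compound 3 to compound 4 (within the scatter). Compound 4 is expected to give about 70%, within a range from 50% to 88%.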

Compound 4, a percentage reported as inhibition, in the whole organism at one dose (the size of the read-out at that dose, not a potency): 77.2%
Estimate against measurement, compound 4: 7.2 percentage points below; the range from low to high includes it.
By their numbers in this assay, from the lowest: compound 1; then compounds 2, 3 and 4 (each within the scatter of the next).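

In this assay, the position on the ring with 2 nitrogen, ortho to the cyano group, now carries (4-chlorophenyl)amino in place of chloro, and the result is a number 3.5 percentage points higher from compound 3 to compound 4 (within the scatter). A single chlorine atom and a group of 8 heavy atoms, with its own aromatic ring, hydrogen-bond donor and hydrogen-bond acceptor, therefore cannot be told apart here at this one dose. So this position accepts a far larger group without a difference that can be read, although nothing measured for these compounds explains this.

From the compounds shown here alone, it remains open whether a plain amino group, a morpholine or a carboxylic acid at this position would also stay within the scatter of compound 3. Also open, going by these compounds, is whether the chlorine on the new ring matters, which a phenylamino group without it would test.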